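Swapping Bromo for Chloro on Compound 1

The source may report more compounds than this note shows. Statements on the series, on what has been measured and on what is new or still open speak of the compounds shown alone.

Compound 1 `O=S(=O)(Nc1ccncc1Nc1cccc(Br)c1)C(F)(F)F` carries a bromo group on its outer benzene ring. Among the compounds with values here, in a functional assay on the whole organism (strain Wistar) with Rattus norvegicus as the target, with stated times of 30 min and 4 h, at a dose of 20 mg/kg by the intraperitoneal route (a lower number here means a weaker effect, a higher number a stronger effect of the compound at the dose given), compound 1 gives 28.5%, the lowest of the three numbers measured so far. Its nearest neighbour is compound 2 `Cc1ccc(Nc2cnccc2NS(=O)(=O)C(F)(F)F)cc1Br`, which gives 44.1%; the step of a number 15.6 percentage points higher from compound 1 to compound 2 (beyond the scatter) comes from a methyl in place of hydrogen on an aromatic carbon. Furthest away is compound 3 `O=S(=O)(Nc1ccncc1Nc1ccc(F)c(Br)c1)C(F)(F)F`, which gives 69.8%; the step of a number 41.3 percentage points higher from compound 1 to compound 3 (beyond the scatter) comes from a fluoro in place of hydrogen on an aromatic carbon. Between these two, the step of a number 25.7 percentage points higher from compound 2 to compound 3 (beyond the scatter) follows from fluoro in place of methyl on an aromatic carbon.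

Compound 4 `O=S(=O)(Nc1ccncc1Nc1cccc(Cl)c1)C(F)(F)F` has not yet been measured. It differs from compound 1 in one place: chloro in place of bromo on an aromatic carbon The change sits on an aromatic carbon of a six-membered aromatic ring of carbon only, meta to a large group. Within the data shown here, none of the measured steps exchanges one halogen for another; each of them puts a methyl or a fluoro in place of hydrogen while the bromo stays in place. There is thus no direct guide to how chloro in place of bromo shifts this assay. In the absence of such evidence, the most cautious expectation is a step from compound 1 to compound 4 that stays within the scatter. The step of a number 1.5 percentage points higher from compound 1 to compound 4 (within the scatter) is expected to be small. Compound 4 is therefore estimated at 30%, with a range from 10% to 55%.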

Compound 4, a percentage reported as activity, at one dose (the size of the read-out at that dose, not a potency): 16.4%
Compound 4: middle estimate off by 13.6 percentage points, on the high side; the range from low to high includes it.
By their numbers in this assay, from the lowest: compound 4; then compound 1; then compound 2; then compound 3.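

Within the data shown here, the step of a number 12.1 percentage points lower from compound 1 to compound 4 (beyond the scatter) is the first in this set to touch the halogen itself, and the first to go downward in this assay, whereas the earlier steps all kept the bromo in place and all raised the number. It shows that this position is sensitive to the identity of the halogen: going from 3-bromophenyl to 3-chlorophenyl exchanges one heavy atom for one heavy atom, adds no hydrogen-bond donor or acceptor and leaves the net charge unchanged, yet the read-out still moves beyond the usual scatter. Nothing measured on these compounds explains this shift, so its cause remains unknown.

Whether a methyl or a fluoro added to the ring of compound 4 would raise the number as it did for compound 1 remains open, since both of those additions are shown only with the bromo present. Also open, as far as these compounds go, is how this same ring position would respond to hydrogen, iodo, a methoxy group, a nitrile or an amine in place of the halogen.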